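The source may report more compounds than this note shows. Statements on the series, on what has been measured and on what is new or still open speak of the compounds shown alone.

Measured compounds:
compound 1, `COc1cccc(N2CCN(CCCCNC(=O)c3ccc(-c4ccsc4)cc3)CC2)c1` — 0.155 h
compound 2, `O=C(NCCCCN1CCN(c2ccccc2O)CC1)c1ccc(-c2ccsc2)cc1` — 0.157 h
compound 3, `O=C(NCCCCN1CCN(c2ccc(O)cc2)CC1)c1ccc(-c2ccsc2)cc1` — 0.19 h

All three numbers come from an ADME assay on microsomes from liver (Rattus norvegicus) for metabolic stability, read by LC-MS, using NADPH (on this read-out higher numbers stand for a longer-lived compound and lower numbers for a shorter-lived compound), and they sit within the scatter of one another: the step of a 1.2-fold higher number from compound 1 to compound 3 (0.09 log units; within the scatter) and the step of a 1.2-fold higher number from compound 2 to compound 3 (0.08 log units; within the scatter) are both too small to count, as is the step of a 1.0-fold higher number from compound 1 to compound 2 (0.01 log units; within the scatter), so compound 3 is not set apart from compound 1 or compound 2 in this assay. Compound 4, `O=C(NCCCCN1CCN(c2ccccc2C(F)(F)F)CC1)c1ccc(-c2ccsc2)cc1`, has not yet been measured. The change is 2-(trifluoromethyl)phenyl in place of 4-hydroxyphenyl on an amine nitrogen in a ring. Among the compounds with values here, every measured step alters the group on that same ring nitrogen, and none of them moved the half-life beyond the scatter, but none of them brings in a 2-(trifluoromethyl)phenyl group, so the new group has no direct precedent here. On that basis, no step beyond the scatter is expected in this assay. The estimated step of a 1.1-fold higher number from compound 3 to compound 4 (0.02 log units; within the scatter) is expected to stay within the scatter. Compound 4 is therefore estimated at 0.2 h, with a range from 0.1 h to 0.45 h.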

Compound 4, half-life: 0.0667 h
Beside the measured number, compound 4's estimate is 3.0-fold (0.48 log units) above it; the whole stated range lies above it.
By their numbers in this assay, from the lowest: compound 4; then compounds 1, 2 and 3 (each within the scatter of the next).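

In this assay, the group on the amine nitrogen in a ring proved able to move the half-life beyond the scatter, which none of the earlier changes there had done: the result shows a 2.8-fold lower number from compound 3 to compound 4 (0.45 log units; beyond the scatter), a 2.4-fold lower number from compound 2 to compound 4 (0.37 log units; beyond the scatter) and a 2.3-fold lower number from compound 1 to compound 4 (0.37 log units; beyond the scatter). These steps are modest, but all three point the same way, so 2-(trifluoromethyl)phenyl sets compound 4 apart as the shortest-lived of the four, while the hydroxyphenyl and methoxyphenyl groups remain within the scatter of one another. Nothing available accounts for this shift.

The compounds shown leave open whether a 4-(trifluoromethyl)phenyl group on that nitrogen would read with compound 4 or with compounds 1, 2 and 3. They also leave open where a plain phenyl or a 2-chlorophenyl group would fall.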